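Hydroxy in Place of Fluoro on a Core Tolerated by Cells

The source may hold more compounds than are shown below. What is called first, only, known or untested is meant among the compounds shown, and "the series" means these compounds.

Compound 1 `O=C1CC(c2ccc(F)cc2)Nc2c(Br)cc(Br)cc21`: in a functional assay on MCF7 cells (Homo sapiens) for cytotoxicity, read by sulforhodamine B assay, with a stated time of 48 h (a lower number here means that less compound is tolerated, a higher number that more compound is tolerated), compound 1 gives > 100000 nM, which is a limit of the assay.
Compound 2 `O=C1CC(c2ccc([N+](=O)[O-])cc2)Nc2c(Br)cc(Br)cc21`: in this assay compound 2 gives > 100000 nM, which is a limit of the assay.
Compound 3 `COc1ccc(C2CC(=O)c3cc(Br)cc(Br)c3N2)cc1`: in this assay compound 3 gives > 100000 nM, which is a limit of the assay.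

Compound 1 thus stands only at a limit, and the other two measured compounds stand at the same limit. The step to compound 4 `O=C1CC(c2ccc(O)cc2)Nc2c(Br)cc(Br)cc21` is hydroxy in place of fluoro on an aromatic carbon. The measured steps that change the same position are a step that the two limits leave unreadable from compound 1 to compound 2, a step that the two limits leave unreadable from compound 1 to compound 3 and a step that the two limits leave unreadable from compound 2 to compound 3, and none of them gives a readable size, since every value is a limit. Three different groups at this position leave the cells untouched at the highest concentration tested, and nothing in the data sets the hydroxy group apart from them. Compound 4 is therefore expected to sit at the same limit, with a number no higher from compound 1 to compound 4 (the limit leaves the size open) as the expected step, because of the limit of > 100000 nM in this assay, at which 3 of the 3 values shown sit. The estimate for compound 4 is 100000 nM, within 30000 nM to 300000 nM.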

Compound 4, concentration lethal to 50% of the cells: > 100000 nM
Compound 4 gave a limit, no number; the forecaster's own chance of this, stated with the estimate: 80%; the middle value sits exactly at the limit.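

Among the compounds shown here, compound 4 gives a limit and no number, so no step from compound 4 to compound 1, compound 2 or compound 3 can be read: the limit of > 100000 nM in this assay, at which 4 of the 4 values shown sit.

The compounds shown leave open where each one's true value lies in this assay, and whether changing this group alters it at all.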